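Removing the Chlorine from the Hydrazone Aryl Ring

The source may report more compounds than this note shows. Statements on the series, on what has been measured and on what is new or still open speak of the compounds shown alone.

Compound 1, `COc1ccc(OC)c(/C=C/c2nnc(Nc3ccc(Cl)cc3)o2)c1`: > 100000 nM
Compound 2, `COc1ccc(OC)c(/C=C/C(=O)N/N=C/c2ccc(Cl)cc2)c1`: 139 nM

In a functional assay on HCC 2998 cells (Homo sapiens) for antiproliferative activity, read by sulforhodamine B assay, with a stated time of 48 h (on this read-out higher numbers stand for weaker inhibition of growth and lower numbers for stronger inhibition of growth), compound 2 gives 139 nM. For compound 1 the assay reports only a limit, > 100000 nM, which is the limit of > 100000 nM in this assay, at which 1 of the 2 values shown sits. For the measured compounds named here, compound 2 therefore holds the only number in this assay, with nothing measured beside it that it could be ranked against.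

Compound 3, `COc1ccc(OC)c(/C=C/C(=O)N/N=C/c2ccccc2)c1`, differs from compound 2 by hydrogen in place of chloro on an aromatic carbon. Going by the values given here, no step between measured compounds is available to gauge a change of this kind. The step from compound 2 to compound 3 is expected to be small to moderate toward weaker inhibition, estimated at a 2.9-fold higher number from compound 2 to compound 3 (0.46 log units; beyond the scatter). Compound 3 is estimated to give 400 nM, expected to lie between 100 nM and 2000 nM.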

Compound 3, concentration for 50% growth inhibition: 2350 nM
Compound 3: the middle estimate sits 5.9-fold (0.77 log units) below what was measured; the whole stated range lies below it.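

The change from 4-chlorophenyl to phenyl, on an aromatic carbon para to a large group, gives a 17-fold higher number from compound 2 to compound 3 (1.23 log units; beyond the scatter) in this assay. For the compounds shown here, this pair is the first with a number at both ends, and it shows that this position is far from indifferent: a single chlorine atom accounts for a large part of the growth inhibition seen with compound 2. Nothing shown here gives a cause for this step.

Going by these compounds, it remains open whether chlorine is special at this place or whether another group, such as fluoro, bromo, methyl, methoxy or an amine, would serve as well. The compounds shown also leave open whether a chloro group on another carbon of the same ring would keep the effect.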